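A few compounds are considered here, and "the series" means these few. Any claim that something is new, unique, unknown or untested is made for them only; others in the source may bear on it.

Among the measured compounds shown here, compound 2 `C[C@@H](Cn1ccc(-c2ccc(C#N)c(Cl)c2)n1)Nc1ncccn1` stands at the higher of the two numbers measured so far: in a functional assay on LNCaP cells (Homo sapiens) for antiproliferative activity, read by CCK-8 assay, with a stated time of 6 days (on this read-out higher numbers stand for weaker inhibition and lower numbers for stronger inhibition), compound 2 gives 1180 nM. For the measured compounds named here, its nearest neighbour is compound 1 `C[C@@H](Cn1ccc(-c2ccc(C#N)c(Cl)c2)n1)Nc1cccnc1`, which in this assay gives 430 nM; the single recorded step is a 2.7-fold higher number from compound 1 to compound 2 (0.44 log units; beyond the scatter). Compound 3 `C[C@@H](Cn1ccc(-c2ccc(C#N)c(Cl)c2)n1)Nc1ncnc2nc[nH]c12` has not yet been measured. Its change from compound 2 is a group of 9 heavy atoms (5 carbon, 4 nitrogen; one five-membered aromatic ring with 2 hetero atoms, one six-membered aromatic ring with 2 hetero atoms) in place of a group of 6 heavy atoms (4 carbon, 2 nitrogen; one six-membered aromatic ring with 2 hetero atoms), on an amine nitrogen. Going by the values given here, no measured step covers an exchange of this kind. Among the compounds with values here, the one step on hand, a 2.7-fold higher number from compound 1 to compound 2 (0.44 log units; beyond the scatter), shows only that the two aryl groups already tried on the amine nitrogen differ by a modest amount; it says nothing about a group that brings a five-membered aromatic ring with 2 hetero atoms and 1 hydrogen-bond donor. The expectation for compound 3 in this assay therefore rests on compound 2 alone and carries a wide range: compound 3 is estimated at 1000 nM, between 320 nM and 3200 nM. The expected step is a 1.2-fold lower number from compound 2 to compound 3 (0.07 log units; within the scatter), which would stay within the scatter.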

Compound 3, half-maximal inhibitory concentration: 960 nM
Compound 3: middle estimate off by 1.0-fold (0.02 log units), on the high side; measured number inside the range.
By their numbers in this assay, from the lowest: compound 1; then compounds 3 and 2 (each within the scatter of the next).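

In this assay, the step of a 1.2-fold lower number from compound 2 to compound 3 (0.09 log units; within the scatter) shows that this amine nitrogen tolerates a larger group with a second aromatic ring and a hydrogen-bond donor in place of pyrimidin-2-yl, with no change beyond the scatter. The added ring and donor do not bring the series back to pyridin-3-yl, as the step of a 2.2-fold higher number from compound 1 to compound 3 (0.35 log units; beyond the scatter) shows, so compound 1 remains the most potent of the three, its steps to both others lying beyond the scatter. No available data account for either step.

Open, as far as these compounds go, is whether an aromatic ring on this amine nitrogen is needed at all, a question that a cyclohexyl or methyl group there would address. Also open, from the compounds shown here alone, is how much the nitrile and chlorine of the shared core contribute to these numbers.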